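Replacing the Diethylcarbamoyl Group with a Boc-Protected Aminopropyl Chain

This account rests on a few compounds, and the source may have more. Where it says the series, first, only, none or still open, it means among the compounds named here.

This account starts from compound 2 `CCN(CC)C(=O)COc1cc2c(-n3nc(-c4ccccn4)nc3N)ncnc2cc1OC`, which in a physicochemical assay for solubility, in phosphate buffer, with a stated time of 18 h, at pH 7.4 (a higher number here means a more soluble compound, a lower number a less soluble compound), gives 42000 nM. For the measured compounds named here, that is the lowest of the two numbers so far, though its nearest neighbour, compound 1 `COc1cc2ncnc(-n3nc(-c4ccccn4)nc3N)c2cc1OCc1ccccc1`, with 58000 nM in this assay, lies within the scatter of it, so no order between the two can be claimed. Going by the values given here, the only measured step is a 1.4-fold lower number from compound 1 to compound 2 (0.14 log units; within the scatter), a change at the same position as the one considered here.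

Compound 3 `COc1cc2ncnc(-n3nc(-c4ccccn4)nc3N)c2cc1OCCCCNC(=O)OC(C)(C)C` has not been measured in this assay. It differs from compound 2 by 3-((tert-butoxycarbonyl)amino)propyl in place of diethylcarbamoyl on a saturated chain carbon bound to an oxygen on an aromatic ring. Among the compounds with values here, the one step that bears on this position, from compound 1 to compound 2, did not move the number beyond the scatter, and nothing else in the set speaks to a chain of this kind. The expectation for compound 3 in this assay is therefore a modest step, if any, and more likely downward than upward, with wide uncertainty.

Compound 3 is estimated to give 30000 nM in this assay, with a range from 12000 nM to 75000 nM, which corresponds to an expected 1.4-fold lower number from compound 2 to compound 3 (0.15 log units; within the scatter).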

Compound 3, solubility: 500 nM
Beside the measured number, compound 3's estimate is 60-fold (1.78 log units) above it; the whole stated range lies above it.
By their numbers in this assay, from the lowest: compound 3; then compounds 2 and 1 (each within the scatter of the next).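

In this assay this position proves far from indifferent: the earlier exchange of phenyl for diethylcarbamoyl stayed within the scatter, whereas 3-((tert-butoxycarbonyl)amino)propyl in place of diethylcarbamoyl gives an 84-fold lower number from compound 2 to compound 3 (1.92 log units; beyond the scatter), and the same group in place of phenyl gives a 120-fold lower number from compound 1 to compound 3 (2.06 log units; beyond the scatter). On a saturated chain carbon bound to an oxygen on an aromatic ring, then, two quite different groups give numbers within the scatter of each other, while this third group stands well apart from both, so the small first step said little about what the position can do. Nothing available accounts for the drop.

The entering group differs from diethylcarbamoyl in several respects at once, including its size and its hydrogen-bond donor, so the compounds shown leave open whether the large step belongs to the propyl chain or to the tert-butoxycarbonyl group at its end. A free primary amine on the same chain, or a carboxylic acid in its place, would begin to separate those two parts, as would a shorter chain carrying the same tert-butoxycarbonyl group.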